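Moving from 2-fluorophenyl to 4-fluorophenyl: working notes

The compounds below may be only part of what the source reports. "The series", "measured", "known", "first", "only" and "open" are said of these compounds alone.

Measured in a functional assay on SGC-7901 cells (Homo sapiens) for antiproliferative activity, read by MTT assay, with a stated time of 24 h; on this read-out lower numbers stand for stronger inhibition and higher numbers for weaker inhibition:
compound 1 `O=C(NNC(=O)c1ccccc1Cl)c1cccc(NS(=O)(=O)c2cnc(O)nc2O)c1`: 6070 nM
compound 2 `O=C(NNC(=O)c1ccccc1F)c1cccc(NS(=O)(=O)c2cnc(O)nc2O)c1`: > 20000 nM

Compound 2 stands at the limit of > 20000 nM in this assay, at which 1 of the 2 values shown sits, so its value is a limit and not a number. The next compound is compound 3 `O=C(NNC(=O)c1cccc(NS(=O)(=O)c2cnc(O)nc2O)c1)c1ccc(F)cc1`, and the change is 4-fluorophenyl in place of 2-fluorophenyl on a carbonyl carbon. Among the measured compounds shown here, only one measured step bears on this, and only indirectly, since it exchanges a group rather than relocating one. That step, an at least 3.2-fold higher number from compound 1 to compound 2 (0.51 log units; beyond the scatter), is beyond the scatter and open-ended. It shows that this assay can respond to a single halogen change in this series. A modest shift towards a lower number is therefore expected, with a real chance of no measurable change. The expected step is an at least 1.2-fold lower number from compound 2 to compound 3 (0.09 log units; that floor lies within the scatter). For compound 3 the estimated value is 16000 nM, with an expected range of 6000 nM to 30000 nM.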

Compound 3, half-maximal inhibitory concentration: > 20000 nM
Compound 3 was reported as a limit; the forecaster's own chance of this, stated with the estimate: 45%; middle value at least 1.2-fold (0.09 log units) from the limit.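

In this assay compound 3 gives > 20000 nM, which is a limit and not a number. Placing 4-fluorophenyl on this carbonyl carbon in place of 2-chlorophenyl gives an at least 3.2-fold higher number from compound 1 to compound 3 (0.51 log units; beyond the scatter), so the open-ended loss seen with 2-fluorophenyl also appears with 4-fluorophenyl. The step between the two fluorophenyl compounds cannot be read, and relocating the fluorine therefore shows no measurable recovery towards compound 1: the limit of > 20000 nM in this assay, at which 2 of the 3 values shown sit.

From the compounds shown here alone, whether compound 2 and compound 3 differ at all beyond the limit stays open. Also open, going by these compounds, is how an unsubstituted phenyl group on this carbonyl carbon would compare with the 2-chlorophenyl group of compound 1.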